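Swapping an Aroyl Group for a Cyclopropylsulfonyl Group

A few compounds are considered here, and "the series" means these few. Any claim that something is new, unique, unknown or untested is made for them only; others in the source may bear on it.

compound 1 `Cc1ccc(C(=O)N2N=C(c3ccc(N4CCN(C)CC4)cc3)CC2c2ccc(N(C)C)cc2)cc1`: -0.7%
compound 2 `CN1CCN(c2ccc(C3=NN(C(=O)c4ccc(F)cc4)C(c4ccc(N(C)C)cc4)C3)cc2)CC1`: 3.5%

In a functional assay on MDA-MB-231 cells (Homo sapiens) for inhibition, read by sulforhodamine B assay, tested at 10 uM (on this read-out lower numbers stand for less inhibition and higher numbers for more inhibition at the one concentration tested (going by the name of the read-out)), compound 1 gives -0.7% and compound 2 gives 3.5%. The step of a number 4.2 percentage points higher from compound 1 to compound 2 (within the scatter) lies within the scatter, so the two compounds cannot be told apart and neither shows meaningful inhibition.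

Compound 3 `CN1CCN(c2ccc(C3=NN(S(=O)(=O)C4CC4)C(c4ccc(N(C)C)cc4)C3)cc2)CC1` differs from compound 2 by cyclopropylsulfonyl in place of (4-fluorophenyl)carbonyl on an amine nitrogen in a ring. For the measured compounds named here, no measured step touches this position: the only measured step changed a group on an aromatic carbon. With nothing to point elsewhere, the step from compound 2 to compound 3 is expected to be small, a number 1.5 percentage points higher from compound 2 to compound 3 (within the scatter). Compound 3 is therefore estimated to give 5%, in the range -15% to 25%.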

Compound 3, a percentage reported as inhibition, at one concentration (the size of the read-out at that concentration, not a potency): 3.7%
Beside the measured number, compound 3's estimate is 1.3 percentage points above it, within the range that was stated.
By their numbers in this assay, from the lowest: compounds 1, 2 and 3 (each within the scatter of the next).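

In this assay, putting cyclopropylsulfonyl in place of the aroyl group on the ring amine nitrogen gives a number 0.2 percentage points higher from compound 2 to compound 3 (within the scatter) and a number 4.4 percentage points higher from compound 1 to compound 3 (within the scatter). A sulfonyl group with a three-membered ring can thus stand on this nitrogen where the carbonyl with its aromatic ring stood, and the three compounds cannot be told apart. Nothing available offers an explanation for this result.

Going by these compounds, since all three numbers lie close together, it remains open whether any group at this nitrogen can raise inhibition, such as a longer alkyl chain or an acyl group carrying an amine.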